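This account rests on a few compounds, and the source may have more. Where it says the series, first, only, none or still open, it means among the compounds named here.

Compound 1 `C=C[C@@](C)(/C=C/c1ccc(OCc2ccccc2)cc1)CCC=C(C)C`: > 52000 nM
Compound 2 `C=C[C@@](C)(/C=C/c1ccc(-c2c(F)c(F)c(F)c(F)c2F)cc1)CCC=C(C)C`: > 52000 nM

Both measured compounds share one core and were tested in a functional assay on HepG2 cells (Homo sapiens) for cytotoxicity, with a stated time of 72 h; on this read-out lower numbers stand for an effect already at smaller amounts and higher numbers for an effect only at larger amounts of compound. For compound 1 the result in this assay is a limit of the assay and not a number: > 52000 nM. Compound 2, which carries a different group on the same ring, likewise gives only a limit in this assay, > 52000 nM. Going by the values given here, compound 1 therefore stands at the limit of > 52000 nM in this assay, at which 2 of the 2 values shown sit, and no measured compound shows a number that would tell where the effect begins.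

Compound 3 `C=C[C@@](C)(/C=C/c1ccc(-c2cccc(Br)c2)cc1)CCC=C(C)C` has not yet been measured in this assay. It differs from compound 1 in one place: 3-bromophenyl in place of benzyloxy on an aromatic carbon. Among the compounds with values here, no step between two measured compounds is available to show what such a change does, so no direction can be drawn from the data; the expectation is a step of no size beyond the usual scatter, meaning the estimated step that the limit leaves unreadable from compound 1 to compound 3 is close to none. Compound 3 is expected to give about 60000 nM in this assay, with a range from 20000 nM to 200000 nM, and quite possibly again only a limit.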

Compound 3, half-maximal effective concentration: > 52000 nM
Compound 3: only a limit was reported; the forecaster's own chance of this, stated with the estimate: 80%; the middle value lies beyond the limit too.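

In this assay compound 3 gives only a limit, > 52000 nM. Going by these compounds alone, compound 1 also gives only a limit, so no step from compound 1 to compound 3 can be read. The three compounds shown share one result: the limit of > 52000 nM in this assay, at which 3 of the 3 values shown sit. They leave open where an effect begins for any of them, and whether 3-bromophenyl in place of benzyloxy changes it.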